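Fluoro on the phenethyl arm: notes toward compound 3

The source may hold more compounds than are shown below. What is called first, only, known or untested is meant among the compounds shown, and "the series" means these compounds.

Compound 1 `Cc1ccc(NC(C(=O)CCc2ccccn2)c2ccccc2Br)c(Cl)c1`: in an assay on isolated protein for binding affinity to corticotropin-releasing factor receptor 1 (Homo sapiens) (a higher number here means a weaker inhibitor, a lower number a stronger inhibitor), compound 1 gives > 10000 nM, a limit of the assay.
Compound 2 `Cc1ccc(NC(C(=O)CCc2ccccc2)c2ccccc2Br)c(Cl)c1`: in this assay compound 2 gives > 10000 nM, again only a limit.

For the measured compounds named here, compound 2 thus stands where every value so far sits, at the limit (the limit of > 10000 nM in this assay, at which 2 of the 2 values shown sit). The step that the two limits leave unreadable from compound 1 to compound 2 cannot be read from two limits. Compound 3 `Cc1ccc(NC(C(=O)CCc2ccc(F)cc2)c2ccccc2Br)c(Cl)c1` differs from compound 2 by fluoro in place of hydrogen on an aromatic carbon, phenethyl to 2-(4-fluorophenyl)ethyl. Going by the values given here, no measured step bears on this change, and nothing here shows a move off the limit. Compound 3 is expected to remain at that limit, with an estimate of 15000 nM and a range from 5000 nM to 50000 nM. The expected step that the limit leaves unreadable from compound 2 to compound 3 is nothing beyond the scatter.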

Compound 3, inhibition constant: > 10000 nM
Compound 3 was reported as a limit; the forecaster's own chance of this, stated with the estimate: 85%; the middle value lies beyond the limit too.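

No new step can be read among compound 1, compound 2 and compound 3, since each result is only a limit of the assay: the limit of > 10000 nM in this assay, at which 3 of the 3 values shown sit.

Which change to the shared core, if any, gives a readable value in this assay remains open.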